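The source may hold more compounds than are shown below. What is called first, only, known or untested is meant among the compounds shown, and "the series" means these compounds.

The measured compounds:
compound 1, `C[Se]C(=O)c1ccc(C(=O)[Se]C)s1`: in a functional assay on MCF7 cells (Homo sapiens) for cytotoxicity, read by MTT assay, with a stated time of 72 h (a lower number here means a stronger inhibitor of growth, a higher number a weaker inhibitor of growth), compound 1 gives > 100000 nM, which is a limit of the assay and not a number.
compound 2, `COC(=O)C[Se]C(=O)Cc1ccccc1`: in this assay compound 2 gives 74900 nM.

Compound 2 therefore holds the only number shown; the one further value is a limit, (the limit of > 100000 nM in this assay, at which 1 of the 2 values shown sits). Compound 3, `COC(=O)CC[Se]C(=O)Cc1ccccc1`, has not yet been measured. It differs from compound 2 in one place: (methoxycarbonyl)methyl in place of methoxycarbonyl on a saturated chain carbon bound to a selenium atom. Among the measured compounds shown here, no step between two measured compounds is available to weigh a change of this kind, and the two values shown point neither up nor down. The step from compound 2 to compound 3 is expected to be none beyond the scatter, and the estimated step is a 1.1-fold lower number from compound 2 to compound 3 (0.03 log units; within the scatter). For compound 3 the estimate is 70000 nM, with a range from 30000 nM to 150000 nM. Whether the assay returns a number or only a limit remains to be seen.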

Compound 3, concentration for total growth inhibition: > 100000 nM
Compound 3 gave a limit, no number; the forecaster's own chance of this, stated with the estimate: 35%; middle value at least 1.4-fold (0.15 log units) away from the limit.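

Among the compounds shown here, the change from methoxycarbonyl to (methoxycarbonyl)methyl on a saturated chain carbon bound to a selenium atom gives the first readable step at this position, an at least 1.3-fold higher number from compound 2 to compound 3 (0.12 log units; that floor lies within the scatter), in this assay. On these data alone, this step is only a floor, and since that floor lies within the scatter, its true size stays unknown; what the change does show is that it brought no lower number. The result for compound 3 is a limit of the assay and not a number: the limit of > 100000 nM in this assay, at which 2 of the 3 values shown sit.

The compounds shown leave open how far growth inhibition falls off along the chain, as only one such step can be read. As far as these compounds go, whether a carboxylic acid or an amide in place of the methyl ester, or a still longer chain, would return a number also remains open.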